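Tert-Butyl for Trifluoromethoxy on a Shared Urea Core

The source may hold more compounds than are shown below. What is called first, only, known or untested is meant among the compounds shown, and "the series" means these compounds.

Compound 1, `Cc1cc(NC(=O)Nc2cccc(C(N)=O)c2)c2ccccc2n1`: in an ADME assay on HEK293 cells (Homo sapiens) for cytotoxicity, with a stated time of 72 h (on this read-out lower numbers stand for an effect already at smaller amounts and higher numbers for an effect only at larger amounts of compound), compound 1 gives > 25000 nM, which is a limit of the assay and not a number.
Compound 2, `COC(=O)c1cccc(NC(=O)Nc2cc(C)nc3ccccc23)c1`: in this assay compound 2 gives 26000 nM.
Compound 3, `Cc1cc(NC(=O)Nc2cccc(OC(F)(F)F)c2)c2ccccc2n1`: in this assay compound 3 gives 22000 nM.

Among the two numbers, compound 3 holds the lower one, and the nearest is a 1.2-fold lower number from compound 2 to compound 3 (0.07 log units; within the scatter), which lies within the scatter; the third value of the set is a limit. Compound 4, `Cc1cc(NC(=O)Nc2cccc(C(C)(C)C)c2)c2ccccc2n1`, differs from compound 3 by tert-butyl in place of trifluoromethoxy on an aromatic carbon.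

Among the measured compounds shown here, no measured step exchanges trifluoromethoxy for tert-butyl. The steps that touch the same aromatic carbon are an at least 1.1-fold lower number from compound 1 to compound 3 (0.05 log units; that floor lies within the scatter) and a 1.2-fold lower number from compound 2 to compound 3 (0.07 log units; within the scatter), both within the scatter, while a step that the limit leaves unreadable from compound 1 to compound 2 cannot be read because of the limit of > 25000 nM in this assay, at which 1 of the 3 values shown sits. Nothing in these steps points to a shift beyond the scatter in this assay in either direction, so the expectation for compound 4 is a 1.1-fold higher number from compound 3 to compound 4 (0.04 log units; within the scatter). Compound 4 is therefore estimated at 24000 nM in this assay, with a range from 12000 nM to 48000 nM, and a reported limit rather than a number remains a real possibility for compound 4.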

Compound 4, half-maximal effective concentration: > 25000 nM
Compound 4 ended at the assay's limit (the forecaster's own chance of this, stated with the estimate: 45%); middle value at least 1.0-fold (0.01 log units) from the limit.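

In this assay, tert-butyl in place of trifluoromethoxy on this aromatic carbon gives an at least 1.1-fold higher number from compound 3 to compound 4 (0.05 log units; that floor lies within the scatter), so this change, the first here to put an all-carbon group with no hydrogen-bond acceptor at this position, shows no shift beyond the scatter. On these data alone, compound 4 gives > 25000 nM, which is a limit of the assay and not a number, so the true size of the step remains unknown and the position now has a second substituent without a numerical result. The steps from compound 2 and from compound 1 to compound 4 cannot be read because of this limit: the limit of > 25000 nM in this assay, at which 2 of the 4 values shown sit.

The compounds shown leave open whether an amine, a carboxylic acid or a longer chain on this aromatic carbon would give a number that stands beyond the scatter from those of compound 2 and compound 3. They also leave open how compound 1 and compound 4 compare with each other, and whether any change at this position can bring the read-out clearly below the values seen so far in this assay.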